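This account rests on a few compounds, and the source may have more. Where it says the series, first, only, none or still open, it means among the compounds named here.

Compound 1 `C/C(=N/Nc1nc(-c2ccc(F)cc2)cs1)c1cccnc1`: 40%
Compound 2 `C/C(=N/Nc1nc(-c2ccc(F)cc2)cs1)c1ccncc1`: 40%
Compound 3 `Fc1ccc(-c2csc(N/N=C\c3c[nH]c4ccccc34)n2)cc1`: 40%

In an in vitro assay on BTI-TN-5B1-4 cells for inhibition of Amine oxidase [flavin-containing] A (Homo sapiens), read by Amplex Red, with a stated time of 15 min, tested at 100 uM (a lower number here means less inhibition, a higher number more inhibition at the concentration tested (going by the name of the read-out)), compound 2 gives 40% and stands level with compound 1 and compound 3 at the digits shown. Among the measured compounds shown here, the only measured step, no change at the digits printed from compound 1 to compound 2 (within the scatter), moved pyridin-4-yl in place of pyridin-3-yl and left the read-out unchanged within the scatter. Compound 4 `C/C(=N/Nc1nc(-c2ccc(F)cc2F)cs1)c1ccncc1` differs from compound 2 by fluoro in place of hydrogen on an aromatic carbon. For the measured compounds named here, no measured step puts a fluoro group in place of a hydrogen, so this change has no direct precedent here; the one step available shows the number in this assay staying level across a small change on the shared core. The step from compound 2 to compound 4 is therefore expected to stay within the scatter: no change at the digits printed from compound 2 to compound 4 (within the scatter). For compound 4 the estimate is 40%, between 25% and 55%.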

Compound 4, a percentage reported as inhibition, at one concentration (the size of the read-out at that concentration, not a potency): 40%
Compound 4: the middle estimate sits on the measured number at the digits printed; the range from low to high includes it.
By their numbers in this assay, from the lowest: compounds 1, 2, 3 and 4 (each within the scatter of the next).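

Putting fluoro in place of hydrogen on an aromatic carbon, ortho to a large group and meta to a fluoro group, brings no change at the digits printed from compound 2 to compound 4 (within the scatter) in this assay. Among the compounds shown here, the earlier step changed only the pyridinyl group, so this is the first sign that the read-out also stays level with a change on the fluorinated ring. Nothing measured here gives a reason for this level result.

As far as these compounds go, whether a larger group on this carbon, such as a methoxy group or an amine, would also leave the read-out level remains open. So does whether these compounds would differ in potency, since a percentage at one concentration does not give it.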